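Benzyl substitution on the ring nitrogen of compound 1

The source may hold more compounds than are shown below. What is called first, only, known or untested is meant among the compounds shown, and "the series" means these compounds.

Measured compounds:
- compound 1 `COc1cc(-c2nc3cc(/C=C4\SC(=O)NC4=O)ccc3[nH]2)cc(OC)c1OC`: 1670 nM
- compound 2 `COc1ccc(-c2nc3cc(/C=C4\SC(=O)NC4=O)ccc3[nH]2)cc1OC`: 7830 nM

Compound 1 gives the lowest of the two numbers in a functional assay on HeLa cells (Homo sapiens) for inhibition, read by MTT assay, with a stated time of 48 h; on this read-out higher numbers stand for weaker inhibition and lower numbers for stronger inhibition; its nearest neighbour is compound 2, and the step of a 4.7-fold higher number from compound 1 to compound 2 (0.67 log units; beyond the scatter) comes from a hydrogen in place of a methoxy on an aromatic carbon, which is beyond the scatter.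

Compound 3 `COc1cc(-c2nc3cc(/C=C4\SC(=O)N(Cc5cccc(C)c5)C4=O)ccc3[nH]2)cc(OC)c1OC` is not yet measured. It differs from compound 1 by 3-methylbenzyl in place of hydrogen on an amide-type nitrogen in a ring. For the measured compounds named here, no measured step touches this part of the shared core: the only step known concerns a methoxy on an aromatic ring, far from the amide-type nitrogen. With nothing to rest on, the expectation for compound 3 is a number close to that of compound 1, with a step of a 1.2-fold higher number from compound 1 to compound 3 (0.08 log units; within the scatter) that is expected to stay within the scatter. The estimate for compound 3 in this assay is therefore 2000 nM, in a range from 500 nM to 8000 nM.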

Compound 3, half-maximal inhibitory concentration: 1440 nM
Compound 3: middle estimate off by 1.4-fold (0.14 log units), on the high side, and the stated range covers the measured number.
By their numbers in this assay, from the lowest: compounds 3 and 1 (each within the scatter of the next); then compound 2.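

For the compounds shown here, the amide-type nitrogen of the five-membered non-aromatic ring, which the earlier compounds left untouched, accepts 3-methylbenzyl in place of hydrogen in this assay with a result that stays within the scatter: a 1.2-fold lower number from compound 1 to compound 3 (0.06 log units; within the scatter) is the step. Removing the hydrogen from this nitrogen and placing a six-membered aromatic ring of carbon there therefore leaves the read-out without a discernible change, whereas the earlier step at a methoxy on the aromatic ring, a 4.7-fold higher number from compound 1 to compound 2 (0.67 log units; beyond the scatter), lies beyond the scatter. Nothing available here accounts for this result.

Going by these compounds, whether a plain benzyl, a longer alkyl chain, or a chain ending in an amine or a carboxylic acid would behave the same on this nitrogen remains open. Also open, on these data alone, is whether the methoxy step keeps its size once 3-methylbenzyl sits on the nitrogen.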